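The source may hold more compounds than are shown below. What is called first, only, known or untested is meant among the compounds shown, and "the series" means these compounds.

Three compounds share one core. Compound 1 `CCCCN(CC)c1cc(C)nc2c1NC(=O)CN2c1ccc(C(C)C)cc1Br`, compound 2 `CCCCN(CC)c1cc(C)nc2c1NC(=O)CN2c1ccc(OC)cc1C` and compound 3 `CCCCN(CC)c1cc(C)nc2c1NC(=O)CN2c1ccc(Br)cc1C` differ only in the aryl group on a ring nitrogen. In an assay on HEK-293T cells for displacement of a labelled ligand from corticotropin-releasing factor receptor 1 (Homo sapiens), read by scintillation counting, with a stated time of 2 h (a higher number here means a weaker inhibitor, a lower number a stronger inhibitor), compound 1 gives 2.4 nM, compound 2 gives 4 nM and compound 3 gives 4.4 nM. For the measured compounds named here, compound 3 has the highest of the three numbers, yet both gaps lie within the scatter, as does the only single-point step, a 1.1-fold higher number from compound 2 to compound 3 (0.04 log units; within the scatter). Compound 4 `CCCCN(CC)c1cc(C)nc2c1NC(=O)CN2c1ccc(C)cc1Br` differs from compound 3 by 2-bromo-4-methylphenyl in place of 4-bromo-2-methylphenyl on a nitrogen on an aromatic ring in a ring. Going by the values given here, no measured step swaps positions in this way, but compound 1 carries the same bromo placement and gives 2.4 nM, within the scatter of compound 3. The step of a 1.4-fold lower number from compound 3 to compound 4 (0.14 log units; within the scatter) is therefore expected to stay within the scatter. For compound 4 the expected value is 3.2 nM, within 1.2 nM to 8.5 nM.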

Compound 4, inhibition constant: 4.4 nM
Estimate against measurement, compound 4: 1.4-fold (0.14 log units) below; measured number inside the range.
By their numbers in this assay, from the lowest: compounds 1, 2, 3 and 4 (each within the scatter of the next).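

For the compounds shown here, exchanging the two groups, 2-bromo-4-methylphenyl in place of 4-bromo-2-methylphenyl, gives the first reading of placement on this aryl ring, and in this assay it shows (no change at the digits printed from compound 3 to compound 4 (within the scatter)). The same holds for 2-bromo-4-methylphenyl in place of 4-methoxy-2-methylphenyl (a 1.1-fold higher number from compound 2 to compound 4 (0.04 log units; within the scatter)) and for methyl in place of isopropyl (a 1.8-fold higher number from compound 1 to compound 4 (0.26 log units; within the scatter)), so all four aryl groups stand within the scatter of one another. Nothing measured here offers an explanation for this result. Still open, from the compounds shown here alone, is whether an amine or a carboxylic acid on this aryl ring would leave the number as flat.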